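The source may report more compounds than this note shows. Statements on the series, on what has been measured and on what is new or still open speak of the compounds shown alone.

Measured so far:
Compound 1, `COc1cc2cc(Oc3ccc(NC(=O)Nc4cccc(C(F)(F)F)c4)cc3)c(C)nc2cc1OC`, in a functional assay on SN12C cells (Homo sapiens) for inhibition, read by sulforhodamine B assay, with a stated time of 48 h (on this read-out higher numbers stand for lower toxicity in this test and lower numbers for higher toxicity in this test), gives > 50000 nM; this value is a limit of the assay, not a number.
Compound 2, `COc1cc2cc(Oc3ccc(NC(=O)Nc4ccc(Cl)c(C(F)(F)F)c4)cc3)c(C)nc2cc1OC`, in this assay gives 26800 nM.

Going by the values given here, compound 2 holds the only number among the two values shown; the other value is a limit, as noted in the limit of > 50000 nM in this assay, at which 1 of the 2 values shown sits. Among the compounds with values here, the one measured step, an at least 1.8-fold lower number from compound 1 to compound 2 (0.27 log units; that floor lies within the scatter), is chloro in place of hydrogen on an aromatic carbon and has a floor that lies within the scatter.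

Compound 3, `COc1cc2cc(Oc3ccc(NC(=O)Nc4ccc(Cl)c(Cl)c4)cc3)c(C)nc2cc1OC`, differs from compound 2 by chloro in place of trifluoromethyl on an aromatic carbon. Within the data shown here, no measured step exchanges a trifluoromethyl for a chloro, so the step from compound 1 to compound 2 bears on it only indirectly, as a change at a nearby aromatic carbon that moved the number little. A step of no more than the scatter is therefore expected in this assay. Compound 3 is estimated at 30000 nM, within 12000 nM to 80000 nM, which means an expected step of a 1.1-fold higher number from compound 2 to compound 3 (0.05 log units; within the scatter).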

Compound 3, concentration lethal to 50% of the cells: > 100000 nM
Compound 3: only a limit was reported; the forecaster's own chance of this, stated with the estimate: 30%; middle value at least 3.3-fold (0.52 log units) away from the limit.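

In this assay, going by these compounds alone, chloro in place of trifluoromethyl on this aromatic carbon, ortho to a chloro group, gives an at least 3.7-fold higher number from compound 2 to compound 3 (0.57 log units; beyond the scatter), so compound 3 reads as less toxic in this test than compound 2; the one earlier step, chloro in place of hydrogen, had a floor within the scatter and could not show a change of this kind. On these data alone, the value of compound 3 is a limit of the assay and not a number, so the full size of this step remains unknown: the limit of > 100000 nM in this assay, at which 1 of the 3 values shown sits. The step between compound 1 and compound 3 cannot be read.

The compounds shown leave open how a nitrile or an amine on this aromatic carbon would read in this assay. They also give no cause for the step, and they do not show whether it would hold with another group in place of the neighbouring chloro.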